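Swapping a thiophene ring for an ethynyl group on a nucleoside core

The source may report more compounds than this note shows. Statements on the series, on what has been measured and on what is new or still open speak of the compounds shown alone.

Compound 1 `COc1ncnc2c1c(-c1ccsc1)cn2[C@@H]1O[C@H](CO)[C@@H](O)[C@H]1O` is the starting point. Among the measured compounds shown here, in a functional assay on A549 cells (Homo sapiens), read by MTT assay, with a stated time of 72 h (on this read-out lower numbers stand for stronger inhibition and higher numbers for weaker inhibition), compound 1 gives 5170 nM, the only numeric value among the three measured compounds. Compound 2 `COc1nc(N)nc2c1c(-c1ccsc1)cn2[C@@H]1O[C@H](CO)[C@@H](O)[C@H]1O` carries an amino group in place of a hydrogen on the core; in this assay compound 2 reaches only the assay limit of > 100000 nM. Compound 3 `CNc1ncnc2c1c(-c1ccsc1)cn2[C@@H]1O[C@H](CO)[C@@H](O)[C@H]1O` has a methylamino group where compound 1 has methoxy; in this assay compound 3 likewise reaches only the assay limit of > 20000 nM. The two measured steps are an at least 19-fold higher number from compound 1 to compound 2 (1.28 log units; beyond the scatter) and an at least 3.8-fold higher number from compound 1 to compound 3 (0.58 log units; beyond the scatter).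

Compound 4 `C#Cc1cn([C@@H]2O[C@H](CO)[C@@H](O)[C@H]2O)c2ncnc(OC)c12` differs from compound 1 at another place: ethynyl in place of thiophen-3-yl on an aromatic carbon. Neither measured step alters the thiophen-3-yl group, so neither bears directly on this change; both show that changes on this core can push the number far upward. The estimate for compound 4 in this assay is therefore uncertain and placed at 12000 nM, with a range from 2500 nM to 60000 nM, meaning an expected step of a 2.3-fold higher number from compound 1 to compound 4 (0.37 log units; beyond the scatter).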

Compound 4, half-maximal inhibitory concentration: 8160 nM
For compound 4 the middle estimate is 1.5-fold (0.17 log units) above the measured one; low and high end bracket the measured number.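

In this assay the change gives a 1.6-fold higher number from compound 1 to compound 4 (0.20 log units; within the scatter), so compound 1 and compound 4 cannot be told apart on this read-out. Among the compounds shown here, this is the first view of this position. The earlier steps shown here changed other places on the core. Here a five-membered aromatic ring with a sulfur atom gives way to a small ethynyl group with no ring, and the number stays within the usual scatter, though nothing shown explains why the two groups read alike.

Still open, as far as these compounds go, is how this position responds to other groups, such as a phenyl ring, a longer alkyne chain or an amine. From the compounds shown here alone, it is also open whether ethynyl would read the same way with methylamino in place of methoxy, or with the added amino group on the core.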